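This account rests on a few compounds, and the source may have more. Where it says the series, first, only, none or still open, it means among the compounds named here.

- compound 1 `Nc1ccccc1NC(=O)c1ccc(CNC(=O)c2n[nH]cc2NC(=O)c2ccccc2Cl)cc1` gives 2110 nM
- compound 2 `COc1ccccc1C(=O)Nc1c[nH]nc1C(=O)NCc1ccc(C(=O)Nc2ccccc2N)cc1` gives 2660 nM

Only these two compounds have been measured, both in a functional assay on A-375 cells (Homo sapiens) for inhibition, read by CCK-8 assay, with a stated time of 72 h; on this read-out lower numbers stand for stronger inhibition and higher numbers for weaker inhibition. There compound 2 gives 2660 nM and stands level with compound 1 , as the gap between the two lies within the scatter.

Compound 3 `Nc1ccccc1NC(=O)c1ccc(CNC(=O)c2n[nH]cc2NC(=O)c2c(F)cccc2F)cc1` has not yet been measured in this assay. It differs from compound 2 at one place: 2,6-difluorophenyl in place of 2-methoxyphenyl on a carbonyl carbon. In words, this is 2,6-difluorophenyl in place of 2-methoxyphenyl on a carbonyl carbon.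

Within the data shown here, one measured step bears on this change: a 1.3-fold higher number from compound 1 to compound 2 (0.10 log units; within the scatter). That step, methoxy in place of chloro on an aromatic carbon, touched the same aromatic group and did not move the number beyond the scatter. Among the measured compounds shown here, it is thin evidence, since no measured compound carries the 2,6-difluorophenyl group. No step beyond the scatter is therefore expected, and no direction is favoured.

The expected step is a 1.2-fold lower number from compound 2 to compound 3 (0.06 log units; within the scatter), which is an estimate within the scatter. The estimate for compound 3 is 2300 nM, with an expected range from 1000 nM to 5000 nM.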

Compound 3, half-maximal inhibitory concentration: 1700 nM
The estimate for compound 3 lay 1.4-fold (0.13 log units) above the measured number; low and high end bracket the measured number.
By their numbers in this assay, from the lowest: compounds 3, 1 and 2 (each within the scatter of the next).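

In this assay, 2,6-difluorophenyl on the carbonyl carbon, in place of 2-methoxyphenyl, gives a 1.6-fold lower number from compound 2 to compound 3 (0.19 log units; within the scatter), and in place of 2-chlorophenyl it gives a 1.2-fold lower number from compound 1 to compound 3 (0.09 log units; within the scatter). This position has therefore now held three different substituted phenyl groups without any step leaving the scatter, so the earlier level standing was not limited to the chloro and methoxy pair. The change from 2-methoxyphenyl to 2,6-difluorophenyl also removes the one hydrogen-bond acceptor counted in the leaving group while keeping the same number of heavy atoms, and the number stays within the scatter; nothing shown here accounts for why these three compounds stand level.

On these data alone, all three compounds keep a six-membered aromatic ring of carbon only at this place, so it remains open whether the level would hold with a group of another kind, such as a primary amine, a carboxylic acid or a longer alkyl chain on the carbonyl carbon. As far as these compounds go, it also remains open whether the same tolerance would hold if the rest of the molecule were changed.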